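Trifluoromethyl for Fluoro on the Phenyl Bearing the Nitrogen

The source may report more compounds than this note shows. Statements on the series, on what has been measured and on what is new or still open speak of the compounds shown alone.

Compound 3 `Fc1ccc(Nc2nc(SCc3ccc(C(F)(F)F)cc3)nc3ccccc23)cc1` gives 36300 nM in a functional assay on MCF7 cells (Homo sapiens) for cytotoxicity, read by MTT assay, with a stated time of 72 h (on this read-out higher numbers stand for weaker inhibition and lower numbers for stronger inhibition), the highest of the three numbers recorded. Compound 1 `FC(F)(F)c1ccc(CSc2nc(Nc3cccc(C(F)(F)F)c3)c3ccccc3n2)cc1` gives 15300 nM, and compound 2 `FC(F)(F)c1ccc(CSc2nc(Nc3cccc(Br)c3)c3ccccc3n2)cc1` gives 25600 nM. Of the measured steps, a 2.4-fold higher number from compound 1 to compound 3 (0.38 log units; beyond the scatter) is modest, while a 1.4-fold higher number from compound 2 to compound 3 (0.15 log units; within the scatter). Compound 4 `FC(F)(F)c1ccc(CSc2nc(Nc3ccc(C(F)(F)F)cc3)c3ccccc3n2)cc1` differs from compound 3 by trifluoromethyl in place of fluoro on an aromatic carbon. The step from compound 1 bears most on this, since compound 1 carries a 3-(trifluoromethyl)phenyl on the nitrogen and compound 4 a 4-(trifluoromethyl)phenyl. A modest step downward is therefore expected for compound 4 a 1.7-fold lower number from compound 3 to compound 4 (0.22 log units; within the scatter), with little certainty because a 2.4-fold higher number from compound 1 to compound 3 (0.38 log units; beyond the scatter) was itself only modest. Compound 4 is estimated at 22000 nM, between 9000 nM and 50000 nM.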

Compound 4, half-maximal inhibitory concentration: 5100 nM
For compound 4 the middle estimate is 4.3-fold (0.63 log units) above the measured one, and the stated range ends above it.
By their numbers in this assay, from the lowest: compound 4; then compounds 1, 2 and 3 (each within the scatter of the next, the first and the last beyond it).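

In this assay trifluoromethyl in place of fluoro gives a 7.1-fold lower number from compound 3 to compound 4 (0.85 log units; beyond the scatter) and so exceeds every earlier step at this phenyl. Where the group sits also counts: 4-(trifluoromethyl)phenyl in place of 3-(trifluoromethyl)phenyl gives a 3.0-fold lower number from compound 1 to compound 4 (0.48 log units; beyond the scatter) while in place of 3-bromophenyl it gives a 5.0-fold lower number from compound 2 to compound 4 (0.70 log units; beyond the scatter) on the same core. Nothing available here accounts for these steps.

As far as these compounds go, whether an amine or a carboxylic acid in the place of trifluoromethyl would keep this level stays open. So does whether the step would hold with another group on the sulfur.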